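A few compounds are considered here, and "the series" means these few. Any claim that something is new, unique, unknown or untested is made for them only; others in the source may bear on it.

Measured so far:

Compound 1, `Cc1nc2cc(OC[C@H](O)CN3CCN(Cc4noc(-c5ccc(Cl)cc5)n4)CC3)ccc2s1`: 2270 nM
Compound 2, `Cc1nc2cc(OC[C@H](O)CN3CCN(Cc4noc(-c5ccc(C(F)(F)F)cc5)n4)CC3)ccc2s1`: 380 nM
Compound 3, `Cc1nc2cc(OC[C@H](O)CN3CCN(Cc4nnc(-c5ccc(Cl)cc5)o4)CC3)ccc2s1`: 8500 nM

All three were tested in a functional assay on mitochondria from heart for inhibition of peroxisomal acyl-coenzyme A oxidase 1 (Rattus norvegicus); on this read-out lower numbers stand for stronger inhibition and higher numbers for weaker inhibition. Compound 1 and compound 2 share one core and differ only by trifluoromethyl in place of chloro on an aromatic carbon; that change gives a 6.0-fold lower number from compound 1 to compound 2 (0.78 log units; beyond the scatter). Compound 3 carries a different core, built from the same atoms joined differently; the difference between the two cores is not broken down here. In this assay compound 3 gives 8500 nM, the highest number of the three, so it is the weakest inhibitor of the set.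

Compound 4, `Cc1nc2cc(OC[C@H](O)CN3CCN(Cc4nnc(-c5ccc(C(F)(F)F)cc5)o4)CC3)ccc2s1`, has not yet been measured. It stands to compound 3 as compound 2 stands to compound 1: the change is trifluoromethyl in place of chloro on an aromatic carbon, at the same place on the same kind of ring. Within the data shown here, since the same change lowered the number from compound 1 to compound 2, a step of similar direction and size is expected from compound 3 to compound 4, namely a 5.7-fold lower number from compound 3 to compound 4 (0.75 log units; beyond the scatter), though with only one earlier example the size is uncertain. Compound 4 is therefore estimated at 1500 nM, likely between 500 nM and 5000 nM.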

Compound 4, half-maximal inhibitory concentration: 4800 nM
For compound 4 the middle estimate is 3.2-fold (0.51 log units) below the measured one; the range from low to high includes it.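

In this assay, putting trifluoromethyl in place of chloro on the core of compound 3 gives a 1.8-fold lower number from compound 3 to compound 4 (0.25 log units; within the scatter), so on this core the change has no effect that can be told apart from the ordinary spread of repeated measurements. The change therefore did not carry over at its earlier size from the core of compound 1 to the core of compound 3, and the two steps can be told apart: the same change on two cores in this assay, a 6.0-fold lower number (0.78 log units; beyond the scatter) from compound 1 to compound 2 and a 1.8-fold lower number (0.25 log units; within the scatter) from compound 3 to compound 4, 3.4-fold (0.53 log units) apart, beyond the scatter of two such steps

Among these compounds, this shows that a step measured on one core is not a safe forecast for the other, but with only two matched pairs, it does not show why the cores respond differently or how a third core would respond.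

The compounds shown leave open whether a nitrile or a methoxy group in place of the chloro would also behave differently on the two cores. They also leave open whether an amine or a carboxylic acid there would give a step of any size on either core.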